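Swapping Methoxy for Chloro on the Outer Aryl Ring

The source may hold more compounds than are shown below. What is called first, only, known or untested is meant among the compounds shown, and "the series" means these compounds.

Of the compounds shown here, two built on one shared core have so far been measured in an ADME assay on MCF-10A cells (Homo sapiens) for cytotoxicity, read by MTT assay, with a stated time of 24 h; on this read-out higher numbers stand for weaker inhibition and lower numbers for stronger inhibition. Compound 1 `Brc1ccc(-c2cc(COc3ccccc3-c3nc4ccccc4s3)on2)cc1` gives 29200 nM, and compound 2 `COc1ccc(-c2cc(COc3ccccc3-c3nc4ccccc4s3)on2)cc1` gives 34100 nM. Among the compounds with values here, the one step between them, a 1.2-fold higher number from compound 1 to compound 2 (0.07 log units; within the scatter), swaps methoxy in place of bromo on an aromatic carbon. On the numbers shown, compound 2 holds the larger of the two figures, but that gap is within the scatter, so the two compounds cannot be told apart on this read-out.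

Compound 3 `Clc1ccc(-c2cc(COc3ccccc3-c3nc4ccccc4s3)on2)cc1` has not yet been measured. Its difference from compound 2 is chloro in place of methoxy on an aromatic carbon. Within the data shown here, the only measured step that bears on this change is the one from compound 1 to compound 2, where bromo and methoxy at the same position gave figures within the scatter of each other. Chloro, like bromo, is a single halogen atom, so no step beyond the scatter is expected in this assay. Compound 3 is expected to give 30000 nM, with a range from 15000 nM to 60000 nM. The expected step of a 1.1-fold lower number from compound 2 to compound 3 (0.06 log units; within the scatter) is thus a small one.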

Compound 3, half-maximal inhibitory concentration: 38800 nM
The estimate for compound 3 lay 1.3-fold (0.11 log units) below the measured number; low and high end bracket the measured number.
By their numbers in this assay, from the lowest: compounds 1, 2 and 3 (each within the scatter of the next).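

This position, para to a large group, has now carried bromo, methoxy and chloro, and in this assay the three compounds cannot be told apart. The step of a 1.1-fold higher number from compound 2 to compound 3 (0.06 log units; within the scatter) replaces methoxy, with its 2 heavy atoms and 1 hydrogen-bond acceptor, by chloro, with 1 heavy atom and no acceptor, while the step of a 1.3-fold higher number from compound 1 to compound 3 (0.12 log units; within the scatter) exchanges one halogen for another, and both steps lie within the scatter, so neither change in this set separates one compound from another on this read-out. Nothing is available that would explain why these figures stay so close together.

The compounds shown leave open whether any group at this position can move the number beyond the scatter, since all three groups here are uncharged and have no ring; an amine, a carboxylic acid or a longer chain such as butoxy would test this. They also leave open whether changes elsewhere on the shared core would matter more than this one does.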